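This account rests on a few compounds, and the source may have more. Where it says the series, first, only, none or still open, it means among the compounds named here.

- Compound 1 `COc1cc(/C=C/C(=O)C(=Cc2ccc(O)cc2)C(=O)/C=C/c2ccc(O)c(OC)c2)ccc1O`: 6320 nM
- Compound 2 `CCOc1ccc(C=C(C(=O)/C=C/c2ccc(O)c(OC)c2)C(=O)/C=C/c2ccc(O)c(OC)c2)cc1OCC`: 10000 nM

In a functional assay, read by spectrophotometry, with a stated time of 5 min (on this read-out higher numbers stand for weaker inhibition and lower numbers for stronger inhibition), compound 2 gives 10000 nM, which cannot be told apart from compound 1: the measurements show a 1.6-fold higher number from compound 1 to compound 2 (0.20 log units; within the scatter). The next compound, compound 3 `COc1cc(/C=C/C(=O)C(=Cc2ccccc2)C(=O)/C=C/c2ccc(O)c(OC)c2)ccc1O`, has not yet been measured. It carries phenyl in place of 3,4-diethoxyphenyl on a double-bonded chain carbon bound to a double-bonded chain carbon.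

For the measured compounds named here, only one measured step bears on this change, since it alters the same place: a 1.6-fold higher number from compound 1 to compound 2 (0.20 log units; within the scatter). Exchanging 4-hydroxyphenyl for 3,4-diethoxyphenyl there moved the number no further than the scatter, so no step beyond the scatter is expected in this assay, although a single step is thin evidence. The estimate means a 1.3-fold lower number from compound 2 to compound 3 (0.10 log units; within the scatter). Compound 3 is expected to give 8000 nM, with an estimated range of 3000 nM to 20000 nM.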

Compound 3, half-maximal inhibitory concentration: 8580 nM
Beside the measured number, compound 3's estimate is 1.1-fold (0.03 log units) below it; measured number inside the range.
By their numbers in this assay, from the lowest: compounds 1, 3 and 2 (each within the scatter of the next).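

In this assay, phenyl in place of 3,4-diethoxyphenyl gives a 1.2-fold lower number from compound 2 to compound 3 (0.07 log units; within the scatter) and this difference is too small to count. Hydrogen in place of hydroxy on an aromatic carbon gives a 1.4-fold higher number from compound 1 to compound 3 (0.13 log units; within the scatter) and this is equally within the scatter, so the ring without any added group joins the other two on equal terms. On this double-bonded chain carbon, a ring carrying hydroxy, a ring carrying two ethoxy groups and a ring with no added group cannot be told apart, which compounds 1 and 2 alone could not show.

From the compounds shown here alone, whether an amine or a carboxylic acid on that ring, or a longer chain in its place, would move the number beyond the scatter stays open. Nothing available here explains why these three compounds cannot be told apart.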